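Flipping Two Ring Stereocentres in Compound 2

This account rests on a few compounds, and the source may have more. Where it says the series, first, only, none or still open, it means among the compounds named here.

Of the compounds shown here, three have been measured in an assay on HEK293 cells for antagonist activity at transient receptor potential cation channel subfamily V member 3 (Homo sapiens), read by FLIPR and calcium flux; a higher number here means a weaker inhibitor, a lower number a stronger inhibitor. Compound 1 `C[C@]1(O)C[C@@](c2cccc(C(F)(F)F)c2)([C@H](O)c2ccccn2)C1` gives 300 nM, and compound 3 `O[C@]1(c2ccccn2)CC[C@@H](c2ccc(C(F)(F)F)cc2)C1` gives 130 nM. Compound 2 `O[C@H](c1ccccn1)[C@]1(c2ccc(C(F)(F)F)cc2)C[C@@H](O)C1` gives 1870 nM, the highest number of the three, so it is the weakest inhibitor here; its gaps to compound 1 and to compound 3 both lie beyond the usual scatter. Compound 1 and compound 3 carry different cores from compound 2, so neither shows what a change inside the core of compound 2 would do.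

For the measured compounds named here, compound 4 `O[C@H](c1ccccn1)[C@]1(c2ccc(C(F)(F)F)cc2)C[C@H](O)C1` is made of exactly the same atoms and bonds as compound 2; the two compounds have the same atoms and bonds and differ only in configuration as drawn: 2 of 3 stereo elements differ; a stereocentre at a saturated ring carbon is drawn r in compound 2 and s in compound 4; a stereocentre at a saturated ring carbon is drawn S in compound 2 and R in compound 4 No pair of measured compounds differs in the same way, so the size and direction of this step cannot be read from the data. Such a change in configuration as drawn can move the number either way, and moves beyond the scatter are common. Compound 4 is therefore estimated at 900 nM in this assay, with an expected range from 200 nM to 4000 nM. That estimate means an expected 2.1-fold lower number from compound 2 to compound 4 (0.32 log units; beyond the scatter), a modest gain whose direction remains uncertain.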

Compound 4, antagonist equilibrium constant: 2240 nM
Estimate against measurement, compound 4: 2.5-fold (0.40 log units) below, within the range that was stated.
By their numbers in this assay, from the lowest: compound 3; then compound 1; then compounds 2 and 4 (each within the scatter of the next).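

In this assay, redrawing two saturated ring carbons gives a 1.2-fold higher number from compound 2 to compound 4 (0.08 log units; within the scatter). Within this pair, the two arrangements therefore cannot be told apart, and the step is the only one here that reads configuration alone, with no group entering or leaving. That makes it a clean comparison: the fact that compounds 2 and 4 differ only in the configuration as drawn

Both ring carbons change together, so the compounds shown leave open what either change would do alone, and whether two separate effects might offset each other. The third stereo element stays the same in this pair and is also untested, as is an amine or a carboxylic acid in place of the hydroxyl on the four-atom-free core position of compound 2.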